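Removing a Fluorine From the Side Chain

This account rests on a few compounds, and the source may have more. Where it says the series, first, only, none or still open, it means among the compounds named here.

Of the compounds shown here, two built on one shared core have been measured in an assay on isolated protein for inhibition of protein kinase C epsilon type (Homo sapiens), read by coupled enzyme assay; on this read-out lower numbers stand for stronger inhibition and higher numbers for weaker inhibition. Compound 1 `CC(C)C(O)Cc1cc(-c2ccnc3[nH]nc(C(F)(F)F)c23)cc(C2(C#N)CC2)c1` carries a 1-hydroxy-2-methylpropyl group on a saturated chain carbon bound to an aromatic carbon; in this assay compound 1 gives 215 nM. Compound 2 `N#CC1(c2cc(CCF)cc(-c3ccnc4[nH]nc(C(F)(F)F)c34)c2)CC1` carries a fluoromethyl group in that place and gives 90 nM in this assay. Within the data shown here, the only step measured so far is a 2.4-fold lower number from compound 1 to compound 2 (0.38 log units; beyond the scatter). Compound 2 therefore stands as the lowest of the two numbers, with compound 1 the nearest, its number higher by a step beyond the scatter.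

Compound 3 `CCc1cc(-c2ccnc3[nH]nc(C(F)(F)F)c23)cc(C2(C#N)CC2)c1` differs from compound 2 by hydrogen in place of fluoro on a saturated chain carbon, two bonds along the chain from an aromatic carbon. Among the measured compounds shown here, no measured step swaps a single fluorine for hydrogen; the one step seen, from compound 1 to compound 2, removed a much larger group along with adding the fluorine, so it bears on this change only loosely. Since the present change is far smaller, a step near the scatter is expected, leaning toward a slightly higher number: the expected step is a 1.3-fold higher number from compound 2 to compound 3 (0.12 log units; within the scatter). Compound 3 is estimated at 120 nM in this assay, with an expected range from 45 nM to 320 nM.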

Compound 3, inhibition constant: 78 nM
Beside the measured number, compound 3's estimate is 1.5-fold (0.19 log units) above it; low and high end bracket the measured number.
By their numbers in this assay, from the lowest: compounds 3 and 2 (each within the scatter of the next); then compound 1.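

In this assay, hydrogen in place of fluoro gives a 1.2-fold lower number from compound 2 to compound 3 (0.06 log units; within the scatter), so the fluorine on this saturated chain carbon makes no difference that this measurement can resolve, and the 2-fluoroethyl and ethyl side chains read alike. Methyl in place of 1-hydroxy-2-methylpropyl gives a 2.8-fold lower number from compound 1 to compound 3 (0.44 log units; beyond the scatter), which is close to the earlier 2.4-fold lower number from compound 1 to compound 2 (0.38 log units; beyond the scatter) and shows that the gap from compound 1 remains whether or not the chain carries the fluorine. No measurement is available to explain either the near-absence of a fluorine effect or the gap from compound 1.

The compounds shown cover only the ethyl, 2-fluoroethyl and larger hydroxy-bearing side chains at this place, so it remains open how a longer plain chain such as propyl, an amine or a carboxylic acid would read here. From the compounds shown here alone, it is also open whether a second fluorine on the same carbon would move the number beyond the scatter, or whether the single fluorine's silence holds on other chains.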